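This account rests on a few compounds, and the source may have more. Where it says the series, first, only, none or still open, it means among the compounds named here.

Measured compounds in an ADME assay on BJ cells (Homo sapiens) for cytotoxicity, read by CellTiter-Glo and resazurin assay, with a stated time of 72 h; on this read-out lower numbers stand for an effect already at smaller amounts and higher numbers for an effect only at larger amounts of compound:
compound 1 `CC(C)N(Cc1cccc(OCCCCCC(=O)O)c1)C(=O)c1ccc(-c2cccc(N(C)C)c2)cc1`: > 26000 nM
compound 2 `CC(C)N(Cc1cccc(OCCCCCC(=O)O)c1)C(=O)c1ccc(-c2cccc3ccccc23)cc1`: < 1.3 nM
compound 3 `CC(C)N(Cc1cccc(OCCCCCC(=O)O)c1)C(=O)c1ccc(-c2ccco2)cc1`: > 26000 nM

In this assay compound 1 gives no number, only a limit of the assay, > 26000 nM. Compound 3 likewise sits at a limit, > 26000 nM. Compound 2 sits at the opposite limit, < 1.3 nM. Compound 1 therefore stands at the high end of the numbers shown, sharing that end with compound 3: the limit of > 26000 nM in this assay, at which 2 of the 3 values shown sit, against (the limit of < 1.3 nM in this assay, at which 1 of the 3 values shown sits).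

Compound 4 `CC(C)N(Cc1cccc(OCCCCCC(=O)O)c1)C(=O)c1ccc(-c2cccc(O)c2)cc1` differs from compound 1 in one place: hydroxy in place of dimethylamino on an aromatic carbon. The steps measured at the same place on the shared core are an at least 20000-fold lower number from compound 1 to compound 2 (4.30 log units; beyond the scatter), an at least 20000-fold higher number from compound 2 to compound 3 (4.30 log units; beyond the scatter) and a step that the two limits leave unreadable from compound 1 to compound 3. Both readable steps run through compound 2; neither involves a hydroxy group, and compound 1 and compound 3 stay together at the high limit. The step that the limit leaves unreadable from compound 1 to compound 4 is therefore expected to be none beyond the scatter, with compound 4 most likely reported again as a limit. The estimate for compound 4 is 30000 nM, within 8000 nM to 100000 nM.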

Compound 4, half-maximal effective concentration: > 26000 nM
Compound 4 was reported as a limit (the forecaster's own chance of this, stated with the estimate: 80%); the middle value does not contradict the limit.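

In this assay compound 4 gives > 26000 nM, a limit of the assay. Hydroxy in place of dimethylamino on this six-membered aromatic ring therefore leaves the compound at the same limit as compound 1, and the steps from compound 1 and from compound 3 to compound 4 cannot be read. The only readable new step is an at least 20000-fold higher number from compound 2 to compound 4 (4.30 log units; beyond the scatter), so among the groups shown only the naphthalen-1-yl of compound 2 stands apart from the high end: the limit of > 26000 nM in this assay, at which 3 of the 4 values shown sit.

Still open, from the compounds shown here alone, is whether an unsubstituted phenyl or a naphthalen-2-yl group at this place would give a readable number between the two limits. Also open, going by these compounds, is whether the low limit of compound 2 holds with an ester or a shorter chain in place of the carboxylic acid chain.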